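The source may report more compounds than this note shows. Statements on the series, on what has been measured and on what is new or still open speak of the compounds shown alone.

Measured compounds:
compound 1, `Cc1cc(S(=O)(=O)/N=C(\N)n2nccc2-c2ccccc2)c(SCc2ccccc2)cc1Cl`, 0.0772 h
compound 2, `Cc1cc(-c2ccccc2)n(/C(N)=N/S(=O)(=O)c2cc(C)c(Cl)cc2SCc2ccccc2)n1`, 0.0938 h

In an ADME assay on microsomes from liver (Homo sapiens) for metabolic stability, read by LC-MS, using NADPH, tested at 5 uM (on this read-out lower numbers stand for a shorter-lived compound and higher numbers for a longer-lived compound), compound 1 gives the lowest of the two numbers, yet its nearest neighbour is compound 2, and the step of a 1.2-fold higher number from compound 1 to compound 2 (0.08 log units; within the scatter) lies within the scatter. The unmeasured compound 3, `Cc1cc(S(=O)(=O)/N=C(\N)n2nccc2-c2ccccc2)c(SCc2cccc(C(F)(F)F)c2)cc1Cl`, differs from compound 1 by trifluoromethyl in place of hydrogen on an aromatic carbon, placed meta to a large group. Among the measured compounds shown here, only the step from compound 1 to compound 2 bears on this, and it changed another group at another place and was within the scatter. A step no larger than the scatter is therefore expected. For compound 3 in this assay the estimate is 0.09 h, ranging from 0.04 h to 0.2 h, an expected step of a 1.2-fold higher number from compound 1 to compound 3 (0.07 log units; within the scatter).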

Compound 3, half-life: 0.0863 h
The estimate for compound 3 lay 1.0-fold (0.02 log units) above the measured number; low and high end bracket the measured number.
By their numbers in this assay, from the lowest: compounds 1, 3 and 2 (each within the scatter of the next).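

Compound 3 is the first compound shown with a change on the benzyl part, and replacing benzyl with 3-(trifluoromethyl)benzyl gives a 1.1-fold higher number from compound 1 to compound 3 (0.05 log units; within the scatter) in this assay. At this place, then, a hydrogen can give way to trifluoromethyl, with its 4 heavy atoms, without a change that can be told from the scatter. No available measurement explains this result.

Going by these compounds, whether a different group at the same place, such as an amine or a carboxylic acid, would leave the number as it is remains open. So does the effect of trifluoromethyl at another place on this ring.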